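Replacing the indole of compound 3 with a fluorophenyl group

The compounds below may be only part of what the source reports. "The series", "measured", "known", "first", "only" and "open" are said of these compounds alone.

Compound 1 `COc1cc(-c2ccnc3c(-c4ccc(C)cc4)cnn23)cc(OC)c1OC`: > 10000 nM
Compound 2 `COc1ccc(-c2cc3nccc(-c4cc(OC)c(OC)c(OC)c4)n3n2)cc1[N+](=O)[O-]`: > 10000 nM
Compound 3 `COc1cc(-c2ccnc3cc(-c4c[nH]c5ccccc45)nn23)cc(OC)c1OC`: 85 nM

In a functional assay on MCF7 cells (Homo sapiens) for inhibition, read by CCK-8 assay, with a stated time of 48 h (a lower number here means a stronger inhibitor, a higher number a weaker inhibitor), compound 1 reaches only the limit of the assay, > 10000 nM, and not a number. Compound 2 likewise stops at the limit, > 10000 nM. Among the measured compounds shown here, compound 3 gives the one real number, 85 nM, so it stands alone as the only compound with a measured value; the limit of > 10000 nM in this assay, at which 2 of the 3 values shown sit, marks where the other two sit. Compound 4 `COc1cc(-c2ccnc3cc(-c4ccc(F)cc4)nn23)cc(OC)c1OC` keeps the shared core of compound 3 and differs in one place: 4-fluorophenyl in place of 1H-indol-3-yl on an aromatic carbon. For the measured compounds named here, no step between measured compounds is known, so the expectation rests on compound 3 alone. Compound 4 is expected to be weaker, with the step of a 24-fold higher number from compound 3 to compound 4 (1.37 log units; beyond the scatter) going beyond the usual scatter. Compound 4 is therefore estimated at 2000 nM, within 300 nM to 10000 nM.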

Compound 4, half-maximal inhibitory concentration: 1280 nM
Beside the measured number, compound 4's estimate is 1.6-fold (0.19 log units) above it; the measured number falls inside the stated range.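

Among the compounds shown here, this is the first comparison here in which only one place changes, and in this assay it gives a 15-fold higher number from compound 3 to compound 4 (1.18 log units; beyond the scatter), so the group on this aromatic carbon strongly affects the result. Activity is weakened but not lost, as compound 4 still gives a real number: the limit of > 10000 nM in this assay, at which 2 of the 4 values shown sit.

The change removes both the hydrogen-bond donor and the five-membered aromatic ring, and the compounds shown cannot separate these two differences. A methyl group on the indole nitrogen would keep the rings but remove the donor, and so could help to tell them apart.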